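Replacing the 4-Methoxyphenyl Group of a Weak Inhibitor

The source may report more compounds than this note shows. Statements on the series, on what has been measured and on what is new or still open speak of the compounds shown alone.

Of the compounds shown here, two sharing one core have been measured in a functional assay on K562 cells (Homo sapiens) for inhibition, read by trypan blue exclusion, with a stated time of 72 h; on this read-out lower numbers stand for stronger inhibition and higher numbers for weaker inhibition. Compound 1 `COc1ccc(Nc2ncc3cc(S(=O)(=O)c4ccc(C)cc4)c(=O)n(C)c3n2)cc1` gives 75000 nM, the higher of the two numbers and so the weaker result. Compound 2 `COc1ccc(Nc2ncc3cc(S(=O)(=O)c4ccc(Cl)cc4)c(=O)n(C)c3n2)cc1` gives 15000 nM.

For the measured compounds named here, the only measured step, a 5.0-fold lower number from compound 1 to compound 2 (0.70 log units; beyond the scatter), comes from chloro in place of methyl on an aromatic carbon, and it is modest.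

Compound 3 `Cc1ccc(S(=O)(=O)c2cc3cnc(Nc4cnc5c(c4)CC(=O)N5)nc3n(C)c2=O)cc1` keeps that methyl and changes a different place instead: a group of 10 heavy atoms (7 carbon, 2 nitrogen, 1 oxygen; one five-membered non-aromatic ring with 1 hetero atom, one six-membered aromatic ring with 1 hetero atom) in place of a group of 8 heavy atoms (7 carbon, 1 oxygen; one six-membered aromatic ring of carbon only), on a nitrogen on an aromatic ring. Going by the values given here, no measured compound tests this replacement, so the direction of any change remains uncertain. Among the compounds with values here, the measured step shows only that one small swap on this core can move the number beyond the scatter. The present swap exchanges a whole ring group, so a step of similar or larger size is expected. A lower number is the tentative expectation, with a higher one not excluded.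

The expected change is a 3.8-fold lower number from compound 1 to compound 3 (0.57 log units; beyond the scatter), and this remains an estimate. For compound 3 the estimated value in this assay is 20000 nM, with an expected range of 2500 nM to 100000 nM.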

Compound 3, half-maximal inhibitory concentration: 15000 nM
Compound 3: middle estimate off by 1.3-fold (0.12 log units), on the high side; low and high end bracket the measured number.
By their numbers in this assay, from the lowest: compounds 2 and 3 (each within the scatter of the next); then compound 1.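

In this assay, the 4-methoxyphenyl group on the nitrogen proves open to change: replacing it with the larger group of two fused rings gives a 5.0-fold lower number from compound 1 to compound 3 (0.70 log units; beyond the scatter). The number on the shared core can therefore be moved from a second place, and not only by putting chloro in place of methyl. The entering group has 1 hydrogen-bond donor and 2 hydrogen-bond acceptors, against 0 donors and 1 acceptor in the group that leaves, but nothing available here connects these counts or any other feature of the group with the change in the number.

Because the whole group was exchanged in a single step, the compounds shown cannot separate the contribution of the six-membered aromatic ring with its hetero atom from that of the five-membered non-aromatic ring. They also leave open what a phenyl ring carrying an amine or a carboxylic acid would do on this nitrogen, and whether chloro in place of methyl would lower the number further when combined with the new group.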